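This account rests on a few compounds, and the source may have more. Where it says the series, first, only, none or still open, it means among the compounds named here.

Two members of this series have so far been run in a functional assay on SK-MEL-28 cells (Homo sapiens) for inhibition, read by sulforhodamine B assay, with a stated time of 48 h; on this read-out higher numbers stand for lower toxicity in this test and lower numbers for higher toxicity in this test. Compound 1 `O=C(Nc1cccc(-n2cc(-c3ccncc3)c(-c3ccc(Cl)c(O)c3)n2)c1)Nc1cccc(C(F)(F)F)c1` carries a hydroxy on its chlorophenyl ring and a trifluoromethylphenyl on the urea. In this assay compound 1 gives only a limit of the assay, > 32500 nM, and no number. Compound 2 `COc1cc(-c2nn(-c3cccc(NC(=O)Nc4ccc(Cl)c(Cl)c4)c3)cc2-c2ccncc2)ccc1Cl` carries a methoxy on the corresponding ring and a dichlorophenyl on the urea. In this assay compound 2 also gives only a limit of the assay, > 50000 nM. Going by the values given here, with both readings at limits, no measured pair differing in one place exists and no measured step can be drawn; the two values sit at the limit of > 32500 nM in this assay, at which 1 of the 2 values shown sits, and at the limit of > 50000 nM in this assay, at which 1 of the 2 values shown sits.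

Compound 3 `O=C(Nc1cccc(-n2cc(-c3ccncc3)c(-c3ccc(Cl)c(O)c3)n2)c1)Nc1ccc(Cl)c(Cl)c1` differs from compound 2 by hydrogen in place of methyl on an oxygen on an aromatic ring, so 4-chloro-3-methoxyphenyl becomes 4-chloro-3-hydroxyphenyl. The step from compound 2 to compound 3 is expected to be a number no higher from compound 2 to compound 3 (the limit leaves the size open), nothing beyond the scatter. Compound 3 is estimated at 50000 nM, between 20000 nM and 120000 nM, most probably reported again as a limit only.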

Compound 3, concentration lethal to 50% of the cells: > 32500 nM
Compound 3: only a limit was reported (the forecaster's own chance of this, stated with the estimate: 75%); the middle value does not contradict the limit.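

In this assay compound 3 also gives only a limit of the assay, > 32500 nM, so neither the step from compound 2 to compound 3 nor the step from compound 1 to compound 3 can be read. The compounds shown leave open whether methoxy to hydroxy, or 3,4-dichlorophenyl in place of 3-(trifluoromethyl)phenyl, changes the read-out in this assay at all.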